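The source may hold more compounds than are shown below. What is called first, only, known or untested is meant among the compounds shown, and "the series" means these compounds.

Three compounds have been measured in a functional assay on L1210 cells (Mus musculus) for inhibition; on this read-out higher numbers stand for weaker inhibition and lower numbers for stronger inhibition:
compound 1 `O=C1/C(=C/c2ccc(F)cc2)CCCc2ccccc21` gives 60300 nM;
compound 2 `O=C1/C(=C/c2ccc(Cl)cc2)CCCc2ccccc21` gives 51800 nM;
compound 3 `O=C1CCCCC/C1=C\c1ccc(F)cc1` gives 291000 nM.

Compound 1 and compound 2 share one core and differ in a single place: chloro in place of fluoro on an aromatic carbon. That change made a 1.2-fold lower number from compound 1 to compound 2 (0.07 log units; within the scatter). Compound 3 is built on a different core; the difference between the two cores is not broken down here. Its number is the highest of the three, and its distance to each of compound 1 and compound 2 lies beyond the scatter.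

Compound 4 `O=C1CCCCC/C1=C\c1ccc(Cl)cc1` has not yet been measured in this assay. It stands to compound 3 as compound 2 stands to compound 1: chloro in place of fluoro on an aromatic carbon. The surroundings are not described in the same words, para to a group of 9 heavy atoms in compound 3 against para to a large group in compound 1, so this counts as the same kind of change rather than the same change. Because a 1.2-fold lower number from compound 1 to compound 2 (0.07 log units; within the scatter) stayed within the scatter, the step expected for compound 4 is a 1.2-fold lower number from compound 3 to compound 4 (0.08 log units; within the scatter). Compound 4 is therefore estimated at 240000 nM, with an expected range from 120000 nM to 500000 nM.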

Compound 4, half-maximal inhibitory concentration: 83000 nM
Estimate against measurement, compound 4: 2.9-fold (0.46 log units) above; the whole stated range lies above it.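

On the core of compound 3, chloro in place of fluoro on the aromatic carbon gave a real, though modest, change in this assay (a 3.5-fold lower number from compound 3 to compound 4 (0.54 log units; beyond the scatter)). The same swap on the core of compound 1 gave a step that stayed within the scatter (a 1.2-fold lower number from compound 1 to compound 2 (0.07 log units; within the scatter)). So the size of this change cannot simply be carried from one core to the other in this series, as the two steps do not agree: the same change on two cores in this assay, a 1.2-fold lower number (0.07 log units; within the scatter) from compound 1 to compound 2 and a 3.5-fold lower number (0.54 log units; beyond the scatter) from compound 3 to compound 4, 3.0-fold (0.48 log units) apart, beyond the scatter of two such steps

Among these compounds, with only two pairs, these results do not show why the two cores respond differently, nor what the same swap would do on a third core.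

The compounds shown carry only fluoro or chloro at this place, so it remains open how a bromo, methyl, methoxy or amine group would read out there. As far as these compounds go, it also remains open whether the gap between the two steps would persist with any of these groups in place of the pair compared here.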